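Swapping furan-2-yl for thiophen-3-yl at the end of the side arm

This account rests on a few compounds, and the source may have more. Where it says the series, first, only, none or still open, it means among the compounds named here.

Of the compounds shown here, two have been measured so far. In a functional assay on MCF7 cells (Homo sapiens) for inhibition, with a stated time of 72 h (on this read-out lower numbers stand for stronger inhibition and higher numbers for weaker inhibition), compound 1 `NC1CCC(Nc2nc(NCc3ccc(-c4ccccc4)cc3)c3ncn(C4CCCC4)c3n2)CC1` gives 583 nM and compound 2 `NC1CCC(Nc2nc(NCc3ccc(-c4ccco4)nc3)c3ncn(C4CCCC4)c3n2)CC1` gives 33 nM, so compound 2 holds the lower number of the pair and is the stronger inhibitor. Going by the values given here, the only measured step is an 18-fold lower number from compound 1 to compound 2 (1.25 log units; beyond the scatter), with 6-(furan-2-yl)pyridin-3-yl in place of 4-phenylphenyl.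

Compound 3 `NC1CCC(Nc2nc(NCc3ccc(-c4ccsc4)nc3)c3ncn(C4CCCC4)c3n2)CC1` changes a much smaller part of compound 2: thiophen-3-yl in place of furan-2-yl on an aromatic carbon. Thiophen-3-yl replaces furan-2-yl on an aromatic carbon, and the rest of the molecule stays the same. The large measured step shows that the number can move a long way when this end of the molecule is rebuilt, but it replaced the whole arm. Among the compounds with values here, no measured step swaps one five-membered aromatic ring for another, so the data give no direction for this change. Both groups are five-membered aromatic rings, so the starting point for an estimate is compound 2 at 33 nM. The expected result is a 1.2-fold higher number from compound 2 to compound 3 (0.08 log units; within the scatter), with no shift beyond the scatter. In this assay compound 3 is expected at 40 nM, within an estimated range of 15 nM to 110 nM.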

Compound 3, half-maximal inhibitory concentration: 100 nM
Compound 3: middle estimate off by 2.5-fold (0.40 log units), on the low side; measured number inside the range.
By their numbers in this assay, from the lowest: compound 2; then compound 3; then compound 1.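

In this assay, the end of the side arm proves sensitive to which five-membered ring it carries: thiophen-3-yl in place of furan-2-yl gives a 3.0-fold higher number from compound 2 to compound 3 (0.48 log units; beyond the scatter), even though both groups have the same heavy-atom count and the same counts of hydrogen-bond donors and acceptors. The advantage over the 4-phenylphenyl arm is not confined to the furan compound, since the thiophene arm still gives a 5.8-fold lower number from compound 1 to compound 3 (0.77 log units; beyond the scatter), although this drop is smaller than the one seen with the furan arm. No measured evidence bears on what lies behind the difference between the furan and thiophene rings.

This swap alters both the ring hetero atom, oxygen to sulfur, and the ring carbon through which the group is attached, so the compounds shown cannot separate these changes; thiophen-2-yl, which would keep the attachment of compound 2 and change only the hetero atom, would pull them apart. The compounds shown also leave open how this position would respond to a ring with more than one hetero atom, such as thiazol-2-yl, or to a plain phenyl on the same pyridine.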